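The source may report more compounds than this note shows. Statements on the series, on what has been measured and on what is new or still open speak of the compounds shown alone.

Measured compounds and their readings in a functional assay on SW480 cells (Homo sapiens) for cytotoxicity, read by MTT assay, with a stated time of 24 h; a higher number here means a weaker inhibitor, a lower number a stronger inhibitor:

compound 1 `C=CC1=C(C(=O)NCCC)C(c2ccc(F)cc2)OC1` — compound 1 gives > 100000 nM
compound 2 `C=CC1=C(C(=O)NCc2ccc(C)cc2)C(c2ccc(F)cc2)OC1` — compound 2 gives > 100000 nM
compound 3 `C=CC1=C(C(=O)O)C(c2ccc(F)cc2)OC1` — compound 3 gives > 100000 nM

Each of these readings is a limit of this assay, not a number. Compound 2 therefore stands at the limit of > 100000 nM in this assay, at which 3 of the 3 values shown sit, together with every other value shown, and nothing in the series separates it from compound 1 or compound 3.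

The step to compound 4 `C=CC1=C(C(=O)Nc2ccccc2OC)C(c2ccc(F)cc2)OC1` is 2-methoxyphenyl in place of 4-methylbenzyl on an amide-type nitrogen. The two measured steps that touch the same part of the shared core, a step that the two limits leave unreadable from compound 1 to compound 2 and a step that the two limits leave unreadable from compound 1 to compound 3, both run between two limits and leave no readable size or direction. Changes at the amide-type nitrogen in this series have so far produced no measurable activity in this assay, so no step beyond the scatter is expected here either, and the most likely outcome for compound 4 is again a limit.

Compound 4 is estimated at 100000 nM, in the range 30000 nM to 300000 nM; the expected step is a number no higher from compound 2 to compound 4 (the limit leaves the size open).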

Compound 4, half-maximal inhibitory concentration: > 100000 nM
Compound 4 ended at the assay's limit; the forecaster's own chance of this, stated with the estimate: 85%; the middle value lies on the limit itself.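

In this assay, within the data shown here, compound 4 gives > 100000 nM, a limit and not a number, so no step to compound 4 from compound 1 or compound 2 can be read. The compounds shown leave open whether any change on the amide-type nitrogen shifts the reading in this assay.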